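This account rests on a few compounds, and the source may have more. Where it says the series, first, only, none or still open, it means among the compounds named here.

Measured compounds and their values:

- compound 1 `Cc1ccc(/C=C/C[C@H]2C[C@@H]([C@@H](O)c3ccccc3)CO[C@@H]2c2ccccc2)cc1C` gives 10000 nM in a functional assay on HeLa cells (Homo sapiens) for cytotoxicity, read by WST assay, with a stated time of 48 h; a higher number here means a weaker inhibitor, a lower number a stronger inhibitor
- compound 2 `COc1cccc([C@H]2OC[C@H]([C@@H](O)c3ccc(OC)c(OC)c3)C[C@@H]2C/C=C/c2ccc(OC)c(OC)c2)c1` gives 21800 nM in this assay
- compound 3 `COc1ccc(/C=C/C[C@@H]2C[C@@H]([C@@H](O)c3ccccc3)CO[C@H]2c2ccc(OC)c(OC)c2)cc1OC` gives 16800 nM in this assay

Compound 1 has the lowest of the three numbers. Its nearest neighbour is compound 3, whose number is higher but only within the usual scatter of this kind of measurement, so the two cannot be ranked against each other. Compound 2 lies furthest away, beyond the scatter, so compound 2 is a weaker inhibitor than compound 1. All three compounds sit in the same weak region of this assay.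

Compound 4 `O[C@@H](c1ccccc1)[C@H]1CO[C@H](c2ccccc2)[C@@H](C/C=C/c2ccccc2F)C1` has not yet been measured. It is reached from compound 1 by a single change: 2-fluorophenyl in place of 3,4-dimethylphenyl on a double-bonded chain carbon bound to a double-bonded chain carbon. Going by the values given here, no pair of measured compounds differs in just one place, so there is no measured step to use as a yardstick for this kind of change. Given that the shared core with varied aryl groups stays in the same weak region across compounds 1, 2 and 3, the step from compound 1 to compound 4 is expected to be small, with no clear direction and possibly none beyond the scatter. The expected step of a 1.3-fold higher number from compound 1 to compound 4 (0.11 log units; within the scatter) reflects this. Compound 4 is therefore estimated to give 13000 nM, in a range from 5000 nM to 40000 nM.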

Compound 4, half-maximal inhibitory concentration: 9730 nM
Compound 4: middle estimate off by 1.3-fold (0.13 log units), on the high side; measured number inside the range.
By their numbers in this assay, from the lowest: compounds 4, 1, 3 and 2 (each within the scatter of the next, the first and the last beyond it).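

Going by these compounds alone, replacing 3,4-dimethylphenyl with 2-fluorophenyl on a double-bonded chain carbon bound to a double-bonded chain carbon gives the first one-place comparison in this assay, with a 1.0-fold lower number from compound 1 to compound 4 (0.01 log units; within the scatter) as its step, so compound 1 and compound 4 cannot be ranked against each other. Within the data shown here, earlier, differences among the aryl groups could be seen only in compounds that differed in more than one place, whereas this pair isolates the aryl group on the chain and shows that this particular exchange, which removes two methyl groups and adds a fluorine, produces no change that can be told from the scatter. No independent measurement is available to explain this result, such as one showing how either group acts in the cells.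

This single step cannot show whether removing the methyl groups and adding the fluorine each leave the number unchanged or instead offset each other, and an unsubstituted phenyl at this place would help separate the two. Both groups are also carbon-only aromatic rings apart from the fluorine, so the compounds leave open whether an amine or a carboxylic acid on that ring would move the number beyond the scatter.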